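Dimethylamino on the Phenyl Ring of Compound 2

A few compounds are considered here, and "the series" means these few. Any claim that something is new, unique, unknown or untested is made for them only; others in the source may bear on it.

Compound 1 `O=C1CS/C(=N\c2csc(-c3ccc(Cl)cc3)c2)N1` carries a hydrogen on the amide-type nitrogen of its ring and gives 17100 nM in a functional assay on HT-29 cells (Homo sapiens) for cytotoxicity, read by MTT assay, with a stated time of 72 h; on this read-out higher numbers stand for weaker inhibition and lower numbers for stronger inhibition. Compound 2 `O=C1CS/C(=N\c2csc(-c3ccc(Cl)cc3)c2)N1c1ccccc1` bears a phenyl on that nitrogen, and in this assay compound 2 gives 41400 nM, the higher of the two numbers recorded; the step of a 2.4-fold higher number from compound 1 to compound 2 (0.38 log units; beyond the scatter) is modest. Compound 3 `CN(C)c1ccc(N2C(=O)CS/C2=N\c2csc(-c3ccc(Cl)cc3)c2)cc1` has not yet been measured. It differs from compound 2 by dimethylamino in place of hydrogen on an aromatic carbon, that is, phenyl to 4-(dimethylamino)phenyl. Within the data shown here, no measured step touches this phenyl ring, so the only guide is the single step, which went upward, and the position of compound 2 at the top of the two numbers. For compound 3 in this assay no step beyond the scatter is expected, and the estimate is 40000 nM, within 14000 nM to 115000 nM, which means an expected step of a 1.0-fold lower number from compound 2 to compound 3 (0.01 log units; within the scatter).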

Compound 3, half-maximal inhibitory concentration: 29200 nM
Estimate against measurement, compound 3: 1.4-fold (0.14 log units) above; the range from low to high includes it.
By their numbers in this assay, from the lowest: compounds 1, 3 and 2 (each within the scatter of the next, the first and the last beyond it).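

In this assay, the step of a 1.4-fold lower number from compound 2 to compound 3 (0.15 log units; within the scatter) stays within the scatter, so dimethylamino para to a large group, on the phenyl ring of compound 2, gives no separable change at this place. The step of a 1.7-fold higher number from compound 1 to compound 3 (0.23 log units; within the scatter) is also within the scatter, whereas a 2.4-fold higher number from compound 1 to compound 2 (0.38 log units; beyond the scatter) lay beyond it, so compound 3 cannot be told apart from either of the other two, even though those two are separated from each other. Nothing given here bears on the reason for these numbers.

The compounds shown leave open how a carboxylic acid or a fluorine at the same place on the phenyl ring would read. They also leave open what a methyl or a longer chain would give on the ring nitrogen in place of the aromatic ring.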